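Aryl substituent change in the shared core: compound 3 to compound 4

A few compounds are considered here, and "the series" means these few. Any claim that something is new, unique, unknown or untested is made for them only; others in the source may bear on it.

Measured compounds in an assay for inhibition of cytochrome P450 1A1 (Homo sapiens), read by fluorescence, using microsomes, with a stated time of 10 min; a higher number here means a weaker inhibitor, a lower number a stronger inhibitor:
compound 1 `COc1cccc(/C=C/C(=O)c2ccc[nH]2)c1` gives 6200 nM
compound 2 `O=C(O)c1ccc(/C=C/C(=O)c2ccc[nH]2)cc1` gives only a limit, > 20000 nM
compound 3 `CN(C)c1ccc(/C=C/C(=O)c2ccc[nH]2)cc1` gives only a limit, > 20000 nM

Compound 3 stands at the limit of this assay, together with compound 2, as recorded in the limit of > 20000 nM in this assay, at which 2 of the 3 values shown sit. Going by the values given here, the single step between measured compounds that differ in one place, a step that the two limits leave unreadable from compound 2 to compound 3, is therefore unreadable, since both ends are limits. Among the compounds with values here, compound 1, which carries methoxy, is the only member with a read number.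

Compound 4 `O=C(/C=C/c1ccc(OC(F)(F)F)cc1)c1ccc[nH]1` differs from compound 3 by trifluoromethoxy in place of dimethylamino on an aromatic carbon. Within the data shown here, no measured step bears directly on trifluoromethoxy in place of dimethylamino; the step from compound 2 to compound 3 shows only that both limits were reached, and compound 1 shows that a weak but measurable inhibition is possible.

With so little to rest on, compound 4 is estimated at 9000 nM, in the range 2500 nM to 30000 nM. The step this implies from the limit of compound 3, an at least 2.2-fold lower number from compound 3 to compound 4 (0.34 log units; beyond the scatter), is an expectation only, and a limit read-out for compound 4 remains a real possibility.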

Compound 4, half-maximal inhibitory concentration: > 20000 nM
Compound 4 gave a limit, no number; the forecaster's own chance of this, stated with the estimate: 35%; middle value at least 2.2-fold (0.34 log units) away from the limit.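

Compound 4 gives only a limit in this assay, not a number, as do compound 2 and compound 3, so no step among these three can be read: the limit of > 20000 nM in this assay, at which 3 of the 4 values shown sit.

The compounds shown leave open how trifluoromethoxy, dimethylamino and carboxy rank against one another in this assay.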